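Methyl to isopropyl at the shared carbon

A few compounds are considered here, and "the series" means these few. Any claim that something is new, unique, unknown or untested is made for them only; others in the source may bear on it.

Compound 3 `CCN(CC)CCCCN/C(C)=N\c1ccnc2cc(Cl)ccc12` and compound 2 `CCN(CC)CCCCN/C(=N\c1ccnc2cc(Cl)ccc12)C(C)C` differ by a single change, (isopropyl in place of methyl on a carbon with a double bond to nitrogen). In an ADME assay on HepG2 cells (Homo sapiens) for cytotoxicity, read by MTT assay, with a stated time of 48 h (a lower number here means a stronger inhibitor, a higher number a weaker inhibitor), compound 3 gives 2.68 ug/mL and compound 2 gives 5.01 ug/mL, a step of a 1.9-fold higher number from compound 3 to compound 2 (0.27 log units; within the scatter). Compound 1 `C/C(=N/c1ccnc2cc(Cl)ccc12)NC1CCN(Cc2ccccc2)CC1` carries a different amine partner on the same core; how its core differs from that of compound 3 is not broken down here. In this assay compound 1 gives 8.07 ug/mL. Compound 4 `CC(C)/C(=N/c1ccnc2cc(Cl)ccc12)NC1CCN(Cc2ccccc2)CC1` is the unmeasured counterpart of compound 1, reached by the same change, (isopropyl in place of methyl on a carbon with a double bond to nitrogen). That change has been measured once and stayed within the scatter, so for compound 4 a step of a 1.7-fold higher number from compound 1 to compound 4 (0.24 log units; within the scatter) is expected, resting on a 1.9-fold higher number from compound 3 to compound 2 (0.27 log units; within the scatter). The estimate for compound 4 in this assay is 14 ug/mL, between 7 ug/mL and 28 ug/mL.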

Compound 4, half-maximal inhibitory concentration: 5.15 ug/mL
Beside the measured number, compound 4's estimate is 2.7-fold (0.43 log units) above it; measured number below the stated range.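

In this assay, isopropyl in place of methyl gives a 1.6-fold lower number from compound 1 to compound 4 (0.20 log units; within the scatter), and the two cores do not agree on this change: the same change on two cores in this assay, a 1.9-fold higher number (0.27 log units; within the scatter) from compound 3 to compound 2 and a 1.6-fold lower number (0.20 log units; within the scatter) from compound 1 to compound 4, 2.9-fold (0.47 log units) apart, beyond the scatter of two such steps

A step read on the core of compound 3 is therefore not a safe guide to the same change on the core of compound 1 in this series. Each step alone stays within the scatter, so the data do not show that the change itself moves the number on either core, and two cores give neither a reason for the gap nor a rule for a third core.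

Open, on these data alone, is whether ethyl or a longer chain on the same carbon would show the same gap between the two cores. Also open, as far as these compounds go, is whether the gap follows the amine partner alone.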